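Quinolin-2-yl in place of 2-methoxyphenyl: working notes

The compounds below may be only part of what the source reports. "The series", "measured", "known", "first", "only" and "open" are said of these compounds alone.

In a functional assay on DU-145 cells (Homo sapiens) for inhibition, read by trypan blue exclusion, with a stated time of 96 h (a lower number here means a stronger inhibitor of growth, a higher number a weaker inhibitor of growth), compound 1 `COc1ccccc1/C=C(/SCc1ccc(F)cc1)C(=O)c1ccc(Br)cc1` gives 10000 nM, level within the scatter with compound 2 `COc1ccccc1/C=C(/Sc1ccc(C)cc1)C(=O)c1ccc(Br)cc1` at 9000 nM. Within the data shown here, compound 3 `O=C(/C(=C\c1ccccc1OCc1ccccc1)SCc1ccc(F)cc1)c1ccc(Br)cc1` gives 1000 nM, so compound 1 sits at the high end of the numbers so far. The unmeasured compound 4 `O=C(/C(=C\c1ccc2ccccc2n1)SCc1ccc(F)cc1)c1ccc(Br)cc1` differs from compound 1 as follows: quinolin-2-yl in place of 2-methoxyphenyl on a double-bonded chain carbon bound to a double-bonded chain carbon. Two measured steps are available. The change on the sulfur gives a 1.1-fold lower number from compound 1 to compound 2 (0.05 log units; within the scatter), but it leaves the 2-methoxyphenyl untouched and says little here. The change of phenyl in place of hydrogen on a saturated chain carbon bound to an oxygen on an aromatic ring gives a 10-fold lower number from compound 1 to compound 3 (1.00 log units; beyond the scatter), and it alone alters the group that leaves in compound 4. Among the measured compounds shown here, no measured compound carries quinolin-2-yl, so that single step is only a loose guide. A smaller step in the same direction is therefore expected, and the estimated step is a 3.3-fold lower number from compound 1 to compound 4 (0.52 log units; beyond the scatter). For compound 4 the expected value is 3000 nM, with an estimated range of 800 nM to 12000 nM.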

Compound 4, concentration for 50% growth inhibition: 25000 nM
Compound 4: the middle estimate sits 8.3-fold (0.92 log units) below what was measured; measured number above the stated range.
By their numbers in this assay, from the lowest: compound 3; then compounds 2 and 1 (each within the scatter of the next); then compound 4.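

In this assay, this place on the double-bonded chain carbon now shows change in both directions: quinolin-2-yl gives a 2.5-fold higher number from compound 1 to compound 4 (0.40 log units; beyond the scatter), whereas phenyl in place of hydrogen on the saturated chain carbon bound to an oxygen gives a 10-fold lower number from compound 1 to compound 3 (1.00 log units; beyond the scatter). Quinolin-2-yl has more heavy atoms than 2-methoxyphenyl and the same hydrogen-bond acceptor count, so a larger group here does not by itself give a lower number, though compound 3 shows that one larger group can. No supporting data bear on the reason for this result.

The compounds shown do not separate the contribution of the ring nitrogen from that of the second ring; naphthalen-2-yl or pyridin-2-yl at this place would address that. Going by these compounds, whether the change on the sulfur behaves the same with quinolin-2-yl also remains open.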